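Ester to tertiary amide on a sulfoxide side chain

A few compounds are considered here, and "the series" means these few. Any claim that something is new, unique, unknown or untested is made for them only; others in the source may bear on it.

Measured so far in an assay on isolated protein for inhibition of Norepinephrine transporter (Rattus norvegicus), read by radioligand binding; on this read-out higher numbers stand for weaker inhibition and lower numbers for stronger inhibition:
compound 1 `COC(=O)C[S+]([O-])CC1CN(C)CCC1c1ccc(Cl)cc1` gives 53 nM
compound 2 `COCC[S+]([O-])CC1CN(C)CCC1c1ccc(Cl)cc1` gives 25 nM
compound 3 `CNC(=O)C[S+]([O-])CC1CN(C)CCC1c1ccc(Cl)cc1` gives 86 nM

Compound 1 stands second highest of the three numbers. Its nearest neighbour is compound 3, reached by a 1.6-fold higher number from compound 1 to compound 3 (0.21 log units; within the scatter), a step inside the scatter; its furthest is compound 2, reached by a 2.1-fold lower number from compound 1 to compound 2 (0.33 log units; beyond the scatter), a step beyond it. Compound 4 `CN1CCC(c2ccc(Cl)cc2)C(C[S+]([O-])CC(=O)N(C)C)C1` is not yet measured. It differs from compound 1 by dimethylamino in place of methoxy on a carbonyl carbon. Among the measured compounds shown here, the measured step that bears on this is the one from compound 1 to compound 3, which exchanges methoxy for methylamino on the same carbonyl carbon and gives a 1.6-fold higher number from compound 1 to compound 3 (0.21 log units; within the scatter), within the scatter. The step from compound 2 to compound 3, a 3.4-fold higher number from compound 2 to compound 3 (0.54 log units; beyond the scatter), also replaces a methoxymethyl by a methylcarbamoyl, but that changes the carbonyl itself and so speaks less directly. On this basis compound 4 is expected to sit close to compound 1, with at most a small shift toward a higher number, a 1.5-fold higher number from compound 1 to compound 4 (0.18 log units; within the scatter). The estimate for compound 4 in this assay is 80 nM, expected between 35 nM and 180 nM.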

Compound 4, inhibition constant: 1250 nM
Estimate against measurement, compound 4: 16-fold (1.19 log units) below; measured number above the stated range.
By their numbers in this assay, from the lowest: compound 2; then compounds 1 and 3 (each within the scatter of the next); then compound 4.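

In this assay, among the compounds shown here, the carbonyl carbon proved far less forgiving than the earlier compounds suggested: methyl in place of hydrogen on the amide-type nitrogen gives a 15-fold higher number from compound 3 to compound 4 (1.16 log units; beyond the scatter), whereas methylamino in place of methoxy had stayed within the scatter. The large change from methoxy to dimethylamino, a 24-fold higher number from compound 1 to compound 4 (1.37 log units; beyond the scatter), therefore appears only once the nitrogen carries a second methyl, and the gap to the methoxymethyl side chain widens to a 50-fold higher number from compound 2 to compound 4 (1.70 log units; beyond the scatter). Nothing available here accounts for this loss of inhibition.

The compounds shown leave open whether the large step depends on the amide hydrogen or on the size of the group on nitrogen. Plain amino or ethylamino on the same carbonyl carbon would bear on that question, as would a longer chain between the sulfur and the carbonyl.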